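The source may hold more compounds than are shown below. What is called first, only, known or untested is meant among the compounds shown, and "the series" means these compounds.

Compound 3 `CC(=O)c1cc(CC2CO2)c(OCCCCC#N)cc1O` gives 62% in an assay on isolated protein for inhibition of leukotriene B4 receptor 1 (Homo sapiens), tested at 10 uM (on this read-out lower numbers stand for less inhibition and higher numbers for more inhibition at the one concentration tested (going by the name of the read-out)), and stands highest of the three compounds measured there. Compound 2 `CCCCCCc1cc(C(C)=O)c(O)cc1OCCCCC#N` gives 51% and compound 1 `CCCCc1cc(C(C)=O)c(O)cc1OCCCCC#N` gives 41%. The measured steps all run toward compound 3: a number 21 percentage points higher from compound 1 to compound 3 (beyond the scatter) and a number 11 percentage points higher from compound 2 to compound 3 (beyond the scatter), while a number 10 percentage points higher from compound 1 to compound 2 (within the scatter). Compound 4 `CC(=O)c1cc(CC(C)O)c(OCCCCC#N)cc1O` differs from compound 3 by 1-hydroxyethyl in place of oxiran-2-yl on a saturated chain carbon bound to an aromatic carbon. Among the measured compounds shown here, no measured step exchanges oxiran-2-yl for another group carrying an oxygen, so the two steps that raised the number by bringing in oxiran-2-yl bear on it only loosely. Compound 4 is therefore expected to give a number close to compound 3, with a number 7 percentage points lower from compound 3 to compound 4 (within the scatter) expected to be small. The estimated value for compound 4 is 55%, in a range from 35% to 75%.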

Compound 4, a percentage reported as inhibition, at one concentration (the size of the read-out at that concentration, not a potency): 10%
The estimate for compound 4 lay 45 percentage points above the measured number; the whole stated range lies above it.
By their numbers in this assay, from the lowest: compound 4; then compounds 1 and 2 (each within the scatter of the next); then compound 3.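

In this assay, the place on a saturated chain carbon bound to an aromatic carbon proves sensitive to a swap of equal heavy-atom count: 1-hydroxyethyl in place of oxiran-2-yl, which removes the ring and adds a hydrogen-bond donor, gives a number 52 percentage points lower from compound 3 to compound 4 (beyond the scatter) as the largest step in the series. The same group also compares poorly with the alkyl chains, with a number 41 percentage points lower from compound 2 to compound 4 (beyond the scatter) and with a number 31 percentage points lower from compound 1 to compound 4 (beyond the scatter) in this place, so carrying an oxygen there does not by itself keep the number up. No evidence at hand accounts for these drops.

The compounds shown do not separate the loss of the ring from the gain of the hydroxyl. A cyclopropyl or 1-methoxyethyl group in this place would bear on that, while an amine would test a different donor.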